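Iodo in Place of Cyanophenyl: Cytotoxicity in HEL Cells

This account rests on a few compounds, and the source may have more. Where it says the series, first, only, none or still open, it means among the compounds named here.

Compound 3 `Cc1cc(-c2cccc(C#N)c2)cn2c(CSCCc3ccccc3)cnc12` is measured in an ADME assay on HEL cells (Homo sapiens) for cytotoxicity, with a stated time of 3 days (a lower number here means that less compound is tolerated, a higher number that more compound is tolerated), only as a limit of the assay: compound 3 gives > 50 ug/mL, which is not a number. This is the limit of > 50 ug/mL in this assay, at which 1 of the 3 values shown sits. Within the data shown here, for comparison, compound 1 `Cc1cc(-c2cccc(F)c2)c2ncc(CSCCc3ccccc3)n2c1` gives 35 ug/mL in this assay, and compound 2 `Cc1cc(-c2ccc(O)cc2)c2ncc(CSCCc3ccccc3)n2c1` gives 13.7 ug/mL, the one measured step being a 2.6-fold lower number from compound 1 to compound 2 (0.41 log units; beyond the scatter). Compound 4 `Cc1cc(I)cn2c(CSCCc3ccccc3)cnc12` differs from compound 3 in a single place: iodo in place of 3-cyanophenyl on an aromatic carbon. Among the measured compounds shown here, the only measured step swaps one aryl group for another and does not bear on an exchange for iodo, so no direction is expected from it. Compound 4 is therefore expected near where compound 3 stands, at an estimated 50 ug/mL (range 25 ug/mL to 100 ug/mL), a step of a number no higher from compound 3 to compound 4 (the limit leaves the size open) that is expected to lie within the scatter.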

Compound 4, half-maximal cytotoxic concentration: > 50 ug/mL
Compound 4: only a limit was reported; the forecaster's own chance of this, stated with the estimate: 55%; the middle value lies on the limit itself.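

The step from compound 3 to compound 4 cannot be read: both compounds give only a limit in this assay, not a number. The compounds shown leave open whether iodo in place of 3-cyanophenyl changes the number at all.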